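A few compounds are considered here, and "the series" means these few. Any claim that something is new, unique, unknown or untested is made for them only; others in the source may bear on it.

Measured in an ADME assay on HEK293 cells (Homo sapiens) for cytotoxicity, with a stated time of 72 h; on this read-out higher numbers stand for an effect only at larger amounts of compound and lower numbers for an effect already at smaller amounts:
- compound 1 `C=C[C@@](C)(/C=C/c1ccc(O)cc1)CC/C=C(\C)C=O`: > 36600 nM
- compound 2 `C=C[C@@](C)(/C=C/c1ccc(O)c(/C=C/C(=O)OCc2ccccc2)c1)CCC=C(C)C`: > 36600 nM

Compound 2 stands only at a limit of the assay, > 36600 nM, and not at a number. Compound 1 likewise gives only a limit, > 36600 nM. Going by the values given here, the measured set therefore amounts to the limit of > 36600 nM in this assay, at which 2 of the 2 values shown sit, and no step between measured compounds can be read from it.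

The next compound is compound 3 `C=C[C@@](C)(/C=C/c1ccc(O)c(/C=C/c2ccc(Cl)c(Cl)c2)c1)CCC=C(C)C`, with 3,4-dichlorophenyl in place of benzyloxycarbonyl on a double-bonded chain carbon bound to a double-bonded chain carbon.

Among the compounds with values here, no measured step bears on this change, so the expectation is a tentative one. A small step towards lower numbers in this assay is expected, and compound 3 may well report only a limit again. This rests on compound 2, whose limit of > 36600 nM leaves the true size of the step open. Estimated from this, the change is an at least 1.2-fold lower number from compound 2 to compound 3 (0.08 log units; that floor lies within the scatter). The expected value for compound 3 is 30000 nM, within an estimated range of 12000 nM to 70000 nM.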

Compound 3, half-maximal effective concentration: > 36600 nM
Compound 3: no number, only a limit; the forecaster's own chance of this, stated with the estimate: 60%; at least 1.2-fold (0.08 log units) between middle value and limit.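

In this assay, going by these compounds alone, compound 3 gives only a limit, > 36600 nM, and compound 2 likewise gives only a limit, so no step between compound 2 and compound 3 can be read. Still open, as far as these compounds go, is where the true values of compound 1, compound 2 and compound 3 lie, and whether 3,4-dichlorophenyl in place of benzyloxycarbonyl changes this read-out at all.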